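The source may hold more compounds than are shown below. What is called first, only, known or untested is meant among the compounds shown, and "the series" means these compounds.

Compounds measured so far:
compound 1 `CCc1cc(C)oc(=O)c1`: > 50000 nM
compound 2 `C#Cc1cc(C)oc(=O)c1`: 2000 nM
compound 3 `Cc1cc(/C=C/c2ccccc2)cc(=O)o1`: > 50000 nM
Not yet measured: compound 4 `CCCCc1cc(C)oc(=O)c1`

In a functional assay on K562 cells (Homo sapiens) for inhibition (on this read-out higher numbers stand for weaker inhibition and lower numbers for stronger inhibition), compound 2 gives 2000 nM. For compound 1 only a limit of the assay is reported, > 50000 nM. For compound 3 the result is likewise a limit, > 50000 nM. Within the data shown here, compound 2 therefore holds the only numerical value; the other two sit at the limit of > 50000 nM in this assay, at which 2 of the 3 values shown sit. Among the measured compounds shown here, one measured step touches compound 2: an at least 25-fold lower number from compound 1 to compound 2 (1.39 log units; beyond the scatter), ethynyl replacing ethyl. The change to compound 4 goes the other way: butyl in place of ethynyl on an aromatic carbon. Since ethyl in compound 1 reached only a limit > 50000 nM, a butyl chain is expected to weaken inhibition again, most likely back to a limit. Compound 4 is expected near 50000 nM, between 10000 nM and 200000 nM, a step of a 25-fold higher number from compound 2 to compound 4 (1.40 log units; beyond the scatter).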

Compound 4, half-maximal inhibitory concentration: > 50000 nM
Compound 4 was reported as a limit; the forecaster's own chance of this, stated with the estimate: 70%; the middle value lies on the limit itself.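

In this assay, butyl in place of ethynyl gives an at least 25-fold higher number from compound 2 to compound 4 (1.39 log units; beyond the scatter), so at this position a longer saturated chain, like ethyl in compound 1, does not match the ethynyl group. Compound 1, compound 3 and compound 4 all end at one limit: the limit of > 50000 nM in this assay, at which 3 of the 4 values shown sit. The step from compound 1 to compound 4 joins two limits and cannot be read. Still open, as far as these compounds go, is whether a nitrile, which also carries a triple bond, or a propynyl group at this position would keep the inhibition seen with compound 2.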